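This account rests on a few compounds, and the source may have more. Where it says the series, first, only, none or still open, it means among the compounds named here.

In a functional assay on RAW264.7 cells (Mus musculus) for inhibition, read by Griess assay, with stated times of 2 h and 24 h (a higher number here means a weaker inhibitor, a lower number a stronger inhibitor), three compounds have been measured so far:

compound 1 `COc1ccc([C@@H]2CC(=O)c3c(O)cc(OCc4cn(Cc5ccccc5C(F)(F)F)nn4)cc3O2)cc1O` gives 12500 nM
compound 2 `COc1ccc([C@@H]2C/C(=N\O)c3c(O)cc(OCc4cn(Cc5ccccc5C)nn4)cc3O2)cc1O` gives 18000 nM
compound 3 `CCCCn1cc(COc2cc(O)c3c(c2)O[C@H](c2ccc(OC)c(O)c2)C/C3=N\O)nn1` gives 8900 nM

Compound 1 stands second highest of the three numbers, but its gaps to compound 3 and to compound 2 are both within the scatter, so the three cannot be ranked against each other. Compound 4 `COc1ccc([C@@H]2CC(=O)c3c(O)cc(OCc4cn(Cc5ccccc5C#N)nn4)cc3O2)cc1O` differs from compound 1 by cyano in place of trifluoromethyl on an aromatic carbon. For the measured compounds named here, the only measured step, a 2.0-fold lower number from compound 2 to compound 3 (0.31 log units; beyond the scatter), alters a different place, the group on the saturated chain carbon bound to the aromatic nitrogen, and compounds 2 and 3 also differ from compound 1 elsewhere in the shared core, so no step bears directly on this change. Even that larger swap moved the number only modestly, so the expected step of a 1.0-fold lower number from compound 1 to compound 4 (0.02 log units; within the scatter) is none beyond the scatter. Compound 4 is therefore estimated at 12000 nM, within 5000 nM to 30000 nM.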

Compound 4, half-maximal inhibitory concentration: 14600 nM
Compound 4: middle estimate off by 1.2-fold (0.09 log units), on the low side, and the stated range covers the measured number.
By their numbers in this assay, from the lowest: compounds 3, 1, 4 and 2 (each within the scatter of the next, the first and the last beyond it).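

In this assay, for the compounds shown here, the change from 2-(trifluoromethyl)benzyl to 2-cyanobenzyl gives a 1.2-fold higher number from compound 1 to compound 4 (0.07 log units; within the scatter) and is the first direct test of this place on the aromatic ring. Here the two groups cannot be told apart, even though cyano has 2 heavy atoms against 4 for trifluoromethyl and brings 1 hydrogen-bond acceptor. No measurement at hand accounts for this result. On these data alone, it remains open whether an amine or a carboxylic acid at this place would move the number beyond the scatter. As far as these compounds go, whether this swap would read the same on the core of compound 2 is also open.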